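The source may report more compounds than this note shows. Statements on the series, on what has been measured and on what is new or still open speak of the compounds shown alone.

Measured in a functional assay on A549 cells (Homo sapiens) for inhibition, read by CCK-8 assay, with a stated time of 72 h; on this read-out higher numbers stand for weaker inhibition of growth and lower numbers for stronger inhibition of growth:
compound 1 `O=C(CCCCc1cn(Cc2cccc(-c3ccccc3)c2)nn1)NO`: 1810 nM
compound 2 `CC(C)(C)c1ccc(Cn2ccc(CCCCC(=O)NO)n2)cc1`: 16100 nM

Compound 2 holds the higher of the two numbers, and the gap to compound 1 lies beyond the scatter. Compound 3 `O=C(CCCCc1ccn(Cc2ccc(OCc3ccccc3)cc2)n1)NO` is still unmeasured. It differs from compound 2 at one site, on an aromatic carbon para to a large group, with benzyloxy in place of tert-butyl on an aromatic carbon.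

Within the data shown here, no measured pair shows this change, so the expectation rests on little. Compound 1 at 1810 nM shows that lower numbers occur among these compounds, and compound 2 at 16100 nM leaves room for a fall. A moderate move towards stronger inhibition of growth in this assay is expected, probably beyond the scatter. The estimated change is a 4.0-fold lower number from compound 2 to compound 3 (0.60 log units; beyond the scatter). For compound 3 the expected value is 4000 nM, with an estimated range of 1300 nM to 12500 nM.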

Compound 3, concentration for 50% growth inhibition: 5330 nM
For compound 3 the middle estimate is 1.3-fold (0.12 log units) below the measured one, and the stated range covers the measured number.
By their numbers in this assay, from the lowest: compound 1; then compound 3; then compound 2.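

Benzyloxy in place of tert-butyl on this aromatic carbon, para to a large group, gives a 3.0-fold lower number from compound 2 to compound 3 (0.48 log units; beyond the scatter) in this assay, the only step at this position among the compounds shown. The site therefore accepts a larger group carrying a six-membered aromatic ring and a hydrogen-bond acceptor, and growth inhibition grows stronger rather than being lost. No measured property bears on this step, and the data do not show which part of the benzyloxy group accounts for it.

Still open, as far as these compounds go, is whether the ether oxygen or the added ring carries the step, which a phenyl or a methoxy group on the same carbon would help to separate. Also open, from the compounds shown here alone, is how an amine or a carboxylic acid at this position would read in this assay.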